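Ring-methyl step in a bis-aryl piperidine oxime ether series

The compounds below may be only part of what the source reports. "The series", "measured", "known", "first", "only" and "open" are said of these compounds alone.

Measured in a functional assay on HeLa cells (Homo sapiens) for inhibition, read by MTT assay, with a stated time of 24 h; on this read-out lower numbers stand for stronger inhibition and higher numbers for weaker inhibition:
- compound 1 `CO/N=C1\C[C@@H](c2ccccc2)N[C@@H](c2ccccc2)[C@@H]1C`: 113000 nM
- compound 2 `CO/N=C1\C[C@@H](c2ccc(Br)cc2)N[C@@H](c2ccc(Br)cc2)[C@@H]1C`: 25000 nM
- compound 3 `CO/N=C1\C[C@@H](c2cccc(F)c2)N[C@@H](c2cccc(F)c2)[C@@H]1C`: 38400 nM

Three compounds share one core and differ only in the two aryl groups. On this assay compound 3 stands second highest of the three numbers. Its nearest neighbour is compound 2, whose number is lower by an amount that sits within the scatter, so the two cannot be ordered. Its furthest neighbour is compound 1, whose number is higher by an amount beyond the scatter. Within the data shown here, no pair in the set differs in a single place, so no step between measured compounds is available to lean on.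

Compound 4 `CO/N=C1/[C@@H](C)[C@H](c2cccc(F)c2)N[C@H](c2cccc(F)c2)[C@H]1C` keeps the two 3-fluorophenyl groups of compound 3 and adds one change: methyl in place of hydrogen on a saturated ring carbon. Nothing measured here shows what a methyl at this position does, and the remaining compounds only trace the effect of the aryl substituents. The expectation for this step is therefore a small one, in either direction, most likely not beyond the scatter of this assay.

For compound 4 the estimated value is 30000 nM, with a range from 10000 nM to 90000 nM, corresponding to an expected step of a 1.3-fold lower number from compound 3 to compound 4 (0.11 log units; within the scatter).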

Compound 4, half-maximal inhibitory concentration: 37900 nM
The estimate for compound 4 lay 1.3-fold (0.10 log units) below the measured number; the measured number falls inside the stated range.
By their numbers in this assay, from the lowest: compounds 2, 4 and 3 (each within the scatter of the next); then compound 1.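

In this assay, methyl in place of hydrogen on a saturated ring carbon, next to the ring atom that bears a 3-fluorophenyl group and two ring bonds from the ring nitrogen, gives a 1.0-fold lower number from compound 3 to compound 4 (0.01 log units; within the scatter), so the two compounds cannot be told apart. Among these compounds, this is the first reading at this position, which the earlier compounds left untouched, as they differ only in their aryl groups; with the two 3-fluorophenyl groups in place, the added methyl leaves no readable mark on this cell read-out. No measurement available here offers an explanation for this result.

Going by these compounds, whether this position accepts more than a methyl stays open: an ethyl, a longer chain, a hydroxymethyl, an amine or a carboxylic acid on the same ring carbon could give a quite different number. On these data alone, it is also open whether the same step holds with the unsubstituted phenyl groups of compound 1 or the 4-bromophenyl groups of compound 2, since this single step rests on one aryl pair.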